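Fluoro on the pendant phenyl: working notes

The compounds below may be only part of what the source reports. "The series", "measured", "known", "first", "only" and "open" are said of these compounds alone.

Three compounds are measured and one is pending. Compound 1 `O=C(Nc1ccc(Oc2ccnc3[nH]ccc23)cc1)c1cn(-c2ccccc2)c2ccccc2c1=O` gives 2250 nM in a functional assay on HepG2 cells (Homo sapiens) for inhibition, read by MTT assay, with a stated time of 72 h; a lower number here means a stronger inhibitor, a higher number a weaker inhibitor. Compound 2 `O=C(Nc1ccc(Oc2ccnc3[nH]ccc23)cc1)c1cn(-c2ccc(F)cc2)c2ccccc2c1=O` carries fluoro in place of hydrogen on an aromatic carbon and gives 450 nM in this assay; the step of a 5.0-fold lower number from compound 1 to compound 2 (0.70 log units; beyond the scatter). Compound 3 `Cn1ccc2c(Oc3ccc(NC(=O)c4cn(-c5ccc(Br)cc5)c5ccccc5c4=O)cc3F)ccnc21` gives 1260 nM in this assay; how the core of compound 3 differs from the core of compound 1 is not broken down here, so only the two values stand side by side.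

Compound 4 `Cn1ccc2c(Oc3ccc(NC(=O)c4cn(-c5ccc(Br)cc5F)c5ccccc5c4=O)cc3F)ccnc21` is not yet measured. It carries fluoro in place of hydrogen on an aromatic carbon. This is the same kind of change as that from compound 1 to compound 2, not the same: there the fluoro sits para to a large group, here it sits ortho to a large group and meta to a bromo group, on a ring that already carries that bromo. For the measured compounds named here, only one such step is on hand, and it was made on a different ring substitution, so a smaller step is expected here than the earlier one; the expectation rests on a 5.0-fold lower number from compound 1 to compound 2 (0.70 log units; beyond the scatter). The step from compound 3 to compound 4 is expected to be a 1.8-fold lower number from compound 3 to compound 4 (0.26 log units; within the scatter). Compound 4 is estimated to give 700 nM in this assay, with a likely range from 280 nM to 1800 nM.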

Compound 4, half-maximal inhibitory concentration: 2510 nM
Beside the measured number, compound 4's estimate is 3.6-fold (0.55 log units) below it; the whole stated range lies below it.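

In this assay, fluoro in place of hydrogen on an aromatic carbon does not carry over from one core to the other with the same size of step: the same change on two cores in this assay, a 5.0-fold lower number (0.70 log units; beyond the scatter) from compound 1 to compound 2 and a 2.0-fold higher number (0.30 log units; within the scatter) from compound 3 to compound 4, 10-fold (1.00 log units) apart, beyond the scatter of two such steps. Read alone, a 2.0-fold higher number from compound 3 to compound 4 (0.30 log units; within the scatter) does not separate the two compounds, so the change from 4-bromophenyl to 4-bromo-2-fluorophenyl shows neither a gain nor a loss in this series. For the compounds shown here, the comparison does not show that the core alone sets the step: only one pair stands on each core, and in compound 4 the fluoro sits ortho to a large group and meta to a bromo group, so core, neighbouring substitution and place of the fluoro vary together.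

The compounds shown leave open how a plain phenyl or a fluorophenyl without the bromo behaves on the core of compound 3, which would set the two cores side by side directly. Also open, on these data alone, is whether an amine, a carboxylic acid or a longer chain on the pendant phenyl is tolerated on either core.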